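Phenyl to cyclohexyl in a two-compound series

The source may hold more compounds than are shown below. What is called first, only, known or untested is meant among the compounds shown, and "the series" means these compounds.

In a physicochemical assay for solubility, in phosphate buffer, with a stated time of 18 h, at pH 7.4 (on this read-out higher numbers stand for higher solubility and lower numbers for lower solubility), compound 1 (`Nc1nc(-c2ccccn2)nn1-c1ncnc2cc(N3CCNCC3)c([N+](=O)[O-])cc12`) gives 4000 nM and compound 2 (`COc1cc2ncnc(-n3nc(-c4ccccc4)nc3N)c2cc1OC`) gives 1000 nM on the same scale. Compound 2 thus holds the lower of the two numbers, and its gap to compound 1 lies beyond the usual scatter. These two compounds differ in more than one place, so their gap cannot be tied to any single change.

Compound 3 (`COc1cc2ncnc(-n3nc(C4CCCCC4)nc3N)c2cc1OC`) differs from compound 2 in one place, with cyclohexyl in place of phenyl on an aromatic carbon. Within the data shown here, no measured pair shows this exchange or any other single change, so the expectation rests mainly on the starting point of compound 2 at 1000 nM in this assay itself. A small upward move is expected, one that stays within the scatter, and the estimated step (a 1.5-fold higher number from compound 2 to compound 3 (0.18 log units; within the scatter)) is accordingly modest. The range is kept wide for the same lack of data. In this assay compound 3 is estimated at 1500 nM within an expected range (400 nM to 6000 nM).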

Compound 3, solubility: 35000 nM
Beside the measured number, compound 3's estimate is 23-fold (1.37 log units) below it; the whole stated range lies below it.
By their numbers in this assay, from the lowest: compound 2; then compound 1; then compound 3.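

In this assay, the exchange of phenyl for cyclohexyl on an aromatic carbon of the five-membered aromatic ring gives a 35-fold higher number from compound 2 to compound 3 (1.54 log units; beyond the scatter). Among these compounds, this is the first step that can be tied to a single place, and it shows that this position is far from indifferent to what it carries. Both groups hold 6 heavy atoms, all carbon, with no hydrogen-bond donors or acceptors and no net charge, so a large move in the read-out accompanies a swap that leaves all these counts unchanged and replaces an aromatic ring with a non-aromatic one; nothing available explains the size of this step.

The compounds shown leave open whether a smaller non-aromatic ring such as cyclopentyl, an open chain such as hexyl, or a cyclohexyl ring bearing an amine or a carboxylic acid would move the read-out in the same direction and to a similar extent. They also leave open whether the same exchange would give a step of like size on the core of compound 1.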